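Swapping Bromo for Methyl in Two Related Compounds

The compounds below may be only part of what the source reports. "The series", "measured", "known", "first", "only" and "open" are said of these compounds alone.

Compound 1 `NC(=O)c1c(NC(=O)c2ccccc2Br)sc2c1CCN(C(=S)Nc1ccccc1Cl)C2` and compound 2 `Cc1ccccc1C(=O)Nc1sc2c(c1C(N)=O)CCN(C(=S)Nc1ccccc1Cl)C2` differ in one place: methyl in place of bromo on an aromatic carbon. In a functional assay on HeLa cells (Homo sapiens) for antiproliferative activity, with a stated time of 24 h (on this read-out higher numbers stand for weaker inhibition and lower numbers for stronger inhibition), compound 1 gives 46900 nM. In this assay compound 2 gives 35300 nM. The step is a 1.3-fold lower number from compound 1 to compound 2 (0.12 log units; within the scatter).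

Compound 3 `NC(=O)c1c(NC(=O)c2ccccc2C(F)(F)F)sc2c1CCN(C(=S)Nc1ccccc1Br)C2` has a different core; the difference between the two cores is not broken down here. In this assay compound 3 gives only a limit, > 50000 nM, which is the limit of > 50000 nM in this assay, at which 1 of the 3 values shown sits. Compound 4 `Cc1ccccc1NC(=S)N1CCc2c(sc(NC(=O)c3ccccc3C(F)(F)F)c2C(N)=O)C1` differs from compound 3 by methyl in place of bromo on an aromatic carbon, the same change as that from compound 1 to compound 2, at a place described in the same words.

Since that earlier step was a 1.3-fold lower number from compound 1 to compound 2 (0.12 log units; within the scatter), the step from compound 3 to compound 4 is expected to be small as well, a step that the limit leaves unreadable from compound 3 to compound 4. Compound 4 is therefore estimated at 60000 nM, with a range from 25000 nM to 150000 nM, and it may again reach only a limit.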

Compound 4, half-maximal inhibitory concentration: 47000 nM
For compound 4 the middle estimate is 1.3-fold (0.11 log units) above the measured one; measured number inside the range.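

On the core of compound 3, swapping bromo for methyl gives an at least 1.0-fold lower number from compound 3 to compound 4 (0.02 log units; that floor lies within the scatter) in this assay. Compound 3 gives > 50000 nM, and that value is a limit of the assay, not a number. The change may therefore carry over between the two cores with a similar size, but this is not shown, and a larger step on the core of compound 3 remains possible: the same change on two cores in this assay, a 1.3-fold lower number (0.12 log units; within the scatter) from compound 1 to compound 2 and an at least 1.0-fold lower number (0.02 log units; that floor lies within the scatter) from compound 3 to compound 4; the limit leaves it open whether they differ

The compounds shown leave open what other groups at this place on the ring would do, such as an amine, a carboxylic acid or a longer chain. They also leave open whether the same swap would act alike on further cores.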